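From 2,5-dimethoxyphenyl to phenyl: compound 1 to compound 4

The source may report more compounds than this note shows. Statements on the series, on what has been measured and on what is new or still open speak of the compounds shown alone.

In a functional assay on HOS-TE85 cells (Homo sapiens) for inhibition, read by CCK-8 assay, with a stated time of 72 h (a higher number here means a weaker inhibitor, a lower number a stronger inhibitor), compound 1 `COc1ccc(OC)c(N2C(=O)CSC2c2cccc(C(=O)NCCCCc3ccccc3)c2)c1` gives > 1000 nM as a limit of the assay and not a number. This places compound 1 at the limit of > 1000 nM in this assay, at which 1 of the 3 values shown sits, and gives it no exact spot on the scale.

In this assay compound 2 `COc1ccccc1N1C(=O)CSC1c1cc(C(=O)NCCCCc2ccccc2)cc(C2CC2)c1` reads 23.5 nM and compound 3 `O=C(NCCCCc1ccccc1)c1cc(F)cc(C2SCC(=O)N2c2ccccn2)c1` reads 14.2 nM and these two values lie within the usual scatter of each other. Neither carries the 2,5-dimethoxyphenyl group, but each also differs from compound 1 elsewhere, so no measured comparison isolates that group.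

Compound 4 `O=C(NCCCCc1ccccc1)c1cccc(C2SCC(=O)N2c2ccccc2)c1` changes compound 1 in one place, with phenyl in place of 2,5-dimethoxyphenyl on an amide-type nitrogen in a ring.

A large step in this assay toward a lower number, meaning stronger inhibition, is expected, and this rests on compound 3 at 14.2 nM without the 2,5-dimethoxyphenyl group. The expected change is an at least 8.3-fold lower number from compound 1 to compound 4 (0.92 log units; beyond the scatter) and it remains uncertain. The estimate for compound 4 is 120 nM with an expected range from 25 nM to 700 nM for this measurement.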

Compound 4, half-maximal inhibitory concentration: 15.9 nM
Compound 4: middle estimate off by 7.5-fold (0.88 log units), on the high side; measured number below the stated range.
By their numbers in this assay, from the lowest: compounds 3, 4 and 2 (each within the scatter of the next). At a limit, above all of these: compound 1.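

In this assay, among these compounds, this is the first pair of compounds that differ only in the group on the amide-type nitrogen of the ring, and it gives an at least 62-fold lower number from compound 1 to compound 4 (1.79 log units; beyond the scatter). Among the compounds shown here, compound 2 and compound 3 also lack the 2,5-dimethoxyphenyl group but differ elsewhere too, so only this pair ties the large step to this one position and this one change. Compound 1 stands at a limit and not at a number, so the step fixes only a minimum size: the limit of > 1000 nM in this assay, at which 1 of the 4 values shown sits.

The compounds shown do not separate the roles of the two methoxy groups, since compound 2 keeps one methoxy group but also differs from compound 4 elsewhere. They also leave open how a phenyl ring bearing an amine or a carboxylic acid would read at this position.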